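The compounds below may be only part of what the source reports. "The series", "measured", "known", "first", "only" and "open" are said of these compounds alone.

Measured so far:
compound 1 `Nc1cc(N)c2nc(-c3ccccc3)c(Oc3ccc(Cl)c(Cl)c3)nc2c1` — 64600 nM
compound 2 `Nc1cc(N)c2nc(-c3ccccc3)c(NCc3ccc(Cl)c(Cl)c3)nc2c1` — 41700 nM
compound 3 `CCOC(=O)[C@H](CCC(=O)O)NC(=O)c1ccc(Sc2nc3cc(N)cc(N)c3nc2-c2ccccc2)cc1` — 33900 nM

All three were read in a functional assay on SK-MEL-28 cells (Homo sapiens) for inhibition, read by sulforhodamine B assay, with a stated time of 48 h; on this read-out lower numbers stand for stronger inhibition of growth and higher numbers for weaker inhibition of growth. Compound 1 has the highest number of the three, yet its gaps to compound 2 and to compound 3 lie within the scatter, so the three cannot be told apart on this read-out. Compound 4 `Nc1cc(N)c2nc(-c3ccccc3)c(Sc3ccc(Cl)c(Cl)c3)nc2c1` is not yet measured; set against compound 1 it carries (3,4-dichlorophenyl)sulfanyl in place of 3,4-dichlorophenoxy on an aromatic carbon. For the measured compounds named here, no step between measured compounds of this kind exists in the set. Compound 3 also carries a sulfanyl link and gives a number in the same band. Compound 4 is therefore expected to move little, a step of a 1.4-fold lower number from compound 1 to compound 4 (0.16 log units; within the scatter). The estimate for compound 4 in this assay is 45000 nM, ranging from 20000 nM to 100000 nM.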

Compound 4, concentration for total growth inhibition: 57500 nM
Beside the measured number, compound 4's estimate is 1.3-fold (0.11 log units) below it; the measured number falls inside the stated range.
By their numbers in this assay, from the lowest: compounds 3, 2, 4 and 1 (each within the scatter of the next).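

In this assay, for the compounds shown here, (3,4-dichlorophenyl)sulfanyl in place of 3,4-dichlorophenoxy on this aromatic carbon gives a 1.1-fold lower number from compound 1 to compound 4 (0.05 log units; within the scatter) and provides the first readable step at this position. The oxygen and sulfur links therefore cannot be told apart on this read-out. No evidence at hand bears on this result.

Going by these compounds, whether a morpholine or a carboxylic acid on this carbon would shift the number remains open. Also open, on these data alone, is whether removing the two chlorine atoms from the phenyl ring would change it.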